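The source may report more compounds than this note shows. Statements on the series, on what has been measured and on what is new or still open speak of the compounds shown alone.

Working notes on the series in an assay on isolated protein for displacement of a labelled ligand from metabotropic glutamate receptor 5 (Homo sapiens), with a stated time of 60 min, tested at 1 uM; on this read-out lower numbers stand for less inhibition and higher numbers for more inhibition at the one concentration tested (going by the name of the read-out).

Three compounds have numbers. Compound 1 `CC1CCN(c2c(S(=O)(=O)c3ccccc3)cnc3ccc(Cl)cc23)CC1` gives 59%; compound 2 `COc1ccc(S(=O)(=O)c2cnc3ccc(Cl)cc3c2N2CCC(C)CC2)cc1OC` gives 61%; compound 3 `CC1CCN(c2c(S(=O)(=O)c3ccc(Cl)cc3)cnc3ccc(Cl)cc23)CC1` gives 92%. Compound 3 stands highest of the three, its nearest neighbour being compound 2 and its furthest compound 1. The step of a number 2 percentage points higher from compound 1 to compound 2 (within the scatter) stays within the scatter, whereas a number 33 percentage points higher from compound 1 to compound 3 (beyond the scatter) and a number 31 percentage points higher from compound 2 to compound 3 (beyond the scatter) are both large.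

The next compound, compound 4 `CC1CCN(c2c(S(=O)(=O)c3cc(F)cc(F)c3)cnc3ccc(Cl)cc23)CC1`, differs from compound 3 by 3,5-difluorophenyl in place of 4-chlorophenyl on a sulfonyl sulfur. Going by the values given here, both large steps so far end at compound 3 and involve the 4-chlorophenyl on the sulfonyl sulfur; compound 4 no longer carries it. Among the compounds with values here, nothing measured shows a 3,5-difluorophenyl in this place, so the change from compound 3 to compound 4 has no direct precedent, and the expectation rests on the fact that compounds without the chloro, compound 1 and compound 2, both sit far lower.

Compound 4 is therefore expected to fall by about a number 26 percentage points lower from compound 3 to compound 4 (beyond the scatter), landing in this assay near 66%, within a range of 45% to 88%.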

Compound 4, a percentage reported as inhibition, at one concentration (the size of the read-out at that concentration, not a potency): 93%
Beside the measured number, compound 4's estimate is 27 percentage points below it, outside the stated range (above it).
By their numbers in this assay, from the lowest: compounds 1 and 2 (each within the scatter of the next); then compounds 3 and 4 (each within the scatter of the next).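

Going by these compounds alone, the 4-chlorophenyl on the sulfonyl sulfur is not the only group that holds the high read-out in this assay, since 3,5-difluorophenyl in its place gives (a number 1 percentage points higher from compound 3 to compound 4 (within the scatter)). The chloro is therefore not needed at this position, and the new group also stands well clear of phenyl (a number 34 percentage points higher from compound 1 to compound 4 (beyond the scatter)) and of 3,4-dimethoxyphenyl (a number 32 percentage points higher from compound 2 to compound 4 (beyond the scatter)); among these four compounds, the two with halogen on this aryl group read high and the two without read low, with none going against this. Nothing available explains why the two halogen-bearing groups read alike.

With a single concentration, whether compound 3 and compound 4 would differ in the size of their effect at any other concentration cannot be told. From the compounds shown here alone, whether a nitrile or a carboxylic acid on this phenyl, or an amine on the sulfonyl sulfur, would hold the read-out stays open.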